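The source may report more compounds than this note shows. Statements on the series, on what has been measured and on what is new or still open speak of the compounds shown alone.

Measured compounds:
compound 1 `CCCCCCCCCCn1cc(Cn2nc(N)c3c(C(F)(F)F)cc(-c4ccccc4)nc32)nn1` — 48.7 ug/mL
compound 2 `Nc1nn(Cc2cn(CC(=O)Nc3ccccc3)nn2)c2nc(-c3ccccc3)cc(C(F)(F)F)c12` — 54.6 ug/mL

In a functional assay on THP-1 cells (Homo sapiens) for cytotoxicity, read by MTT assay, with a stated time of 24 h (on this read-out higher numbers stand for weaker inhibition and lower numbers for stronger inhibition), compound 1 gives 48.7 ug/mL, and compound 2 gives 54.6 ug/mL. Among the compounds with values here, compound 1 is the reference point of the pair; its only measured neighbour is compound 2, and the step of a 1.1-fold higher number from compound 1 to compound 2 (0.05 log units; within the scatter) leaves the two within the scatter of each other, so no order between them can be read from these numbers.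

The next compound in the series is compound 3 `Nc1nn(Cc2cn(CC(=O)Nc3cccc(F)c3)nn2)c2nc(-c3ccccc3)cc(C(F)(F)F)c12`. Relative to compound 1 the change is (3-fluorophenyl)carbamoyl in place of nonyl on a saturated chain carbon bound to an aromatic nitrogen. Within the data shown here, the one step that bears on this is the replacement of nonyl by phenylcarbamoyl at the same place, a 1.1-fold higher number from compound 1 to compound 2 (0.05 log units; within the scatter), which produced no movement beyond the scatter. Compound 3 carries the same carbamoyl group with one fluorine added on its ring, and nothing in the measured pair shows that a fluorine on that ring moves the number. The expected step of a 1.1-fold higher number from compound 1 to compound 3 (0.03 log units; within the scatter) is therefore small, with no direction beyond the scatter. Compound 3 is estimated at 52 ug/mL, with a range from 30 ug/mL to 90 ug/mL.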

Compound 3, half-maximal inhibitory concentration: 99.5 ug/mL
The estimate for compound 3 lay 1.9-fold (0.28 log units) below the measured number; the whole stated range lies below it.
By their numbers in this assay, from the lowest: compounds 1, 2 and 3 (each within the scatter of the next, the first and the last beyond it).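

In this assay, within the data shown here, the exchange of nonyl for (3-fluorophenyl)carbamoyl gives a 2.0-fold higher number from compound 1 to compound 3 (0.31 log units; beyond the scatter) and so becomes the first change on this saturated chain carbon bound to an aromatic nitrogen to clear the scatter, though only modestly. Fluoro in place of hydrogen on an aromatic carbon gives a 1.8-fold higher number from compound 2 to compound 3 (0.26 log units; within the scatter) and therefore cannot be read as an effect of its own. With compound 2 within the scatter of both compound 1 and compound 3, only the whole group exchange separates two compounds here, and nothing measured on these compounds accounts for that separation.

Still open, as far as these compounds go, is whether a chlorine or a methoxy group on the same ring would separate from compound 1 as the fluorine-bearing group does, or would stay within the scatter as the unsubstituted phenylcarbamoyl does. Also open, from the compounds shown here alone, is how the number responds when a carboxylic acid or an amine stands in place of the phenyl ring, or when the nonyl group gives way to a longer or shorter alkyl chain.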